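Bromo for Trifluoromethyl on the Benzyl Arm

This account rests on a few compounds, and the source may have more. Where it says the series, first, only, none or still open, it means among the compounds named here.

Measured so far:
Compound 1, `Cc1cc(/C=C2\SC(=S)N(Cc3ccc(C(F)(F)F)cc3)C2=O)c(C)n1-c1ccc(O)c(C(=O)O)c1`, gives 45900 nM in an ADME assay on MT2 cells (Homo sapiens) for cytotoxicity, read by XTT assay, with a stated time of 4 days; on this read-out higher numbers stand for lower toxicity in this test and lower numbers for higher toxicity in this test.
Compound 2, `Cc1cc(/C=C2\SC(=S)N(Cc3ccc(Br)cc3)C2=O)c(C)n1-c1ccc(O)c(C(=O)O)c1`, gives 94400 nM in this assay.
Compound 3, `Cc1cc(/C=C2\SC(=S)N(Cc3ccccc3C(F)(F)F)C2=O)c(C)n1-c1ccc(O)c(C(=O)O)c1`, gives 28800 nM in this assay.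

One structural change is shared. From compound 1 to compound 2 the change is bromo in place of trifluoromethyl on an aromatic carbon, and in this assay it made a 2.1-fold higher number from compound 1 to compound 2 (0.31 log units; beyond the scatter). Compound 3 and compound 1 carry the same atoms joined differently: 2-(trifluoromethyl)phenyl in place of 4-(trifluoromethyl)phenyl on a saturated chain carbon bound to an amide-type nitrogen in a ring, with a 1.6-fold lower number from compound 1 to compound 3 (0.20 log units; within the scatter). Compound 4, `Cc1cc(/C=C2\SC(=S)N(Cc3ccccc3Br)C2=O)c(C)n1-c1ccc(O)c(C(=O)O)c1`, is unmeasured and differs from compound 3 by bromo in place of trifluoromethyl on an aromatic carbon. The place of the change is not the same as before: in the earlier pair it sits para to a large group, here ortho to a large group, so this is the same kind of change rather than the same one. Because a 2.1-fold higher number from compound 1 to compound 2 (0.31 log units; beyond the scatter) went toward a higher number, a step of similar direction and size is expected here, a 1.7-fold higher number from compound 3 to compound 4 (0.24 log units; within the scatter), though a single earlier pair is a thin footing. For compound 4 in this assay the estimate is 50000 nM, expected to fall between 24000 nM and 120000 nM.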

Compound 4, half-maximal cytotoxic concentration: 25700 nM
For compound 4 the middle estimate is 1.9-fold (0.29 log units) above the measured one; the measured number falls inside the stated range.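

In this assay, bromo in place of trifluoromethyl gave a 1.1-fold lower number from compound 3 to compound 4 (0.05 log units; within the scatter), and the gap between this step and the earlier one is no larger than measurement scatter allows: the same change on two cores in this assay, a 2.1-fold higher number (0.31 log units; beyond the scatter) from compound 1 to compound 2 and a 1.1-fold lower number (0.05 log units; within the scatter) from compound 3 to compound 4, 2.3-fold (0.36 log units) apart, within the scatter of two such steps. This means the change shows no measurable dependence on whether it sits on the 4-substituted or the 2-substituted benzyl arm, but two pairs cannot prove that it carries over reliably, since only the first step is beyond the scatter. The other new steps concern the arm itself: 2-bromophenyl in place of 4-bromophenyl gave a 3.7-fold lower number from compound 2 to compound 4 (0.57 log units; beyond the scatter), which is beyond the scatter, whereas 2-bromophenyl in place of 4-(trifluoromethyl)phenyl gave a 1.8-fold lower number from compound 1 to compound 4 (0.25 log units; within the scatter), which is within it.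

The compounds shown leave open how a chloro, methyl or nitrile group would compare with bromo and trifluoromethyl on this arm. They also leave open whether the same change would behave alike with a longer chain in place of the benzyl link.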